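A few compounds are considered here, and "the series" means these few. Any claim that something is new, unique, unknown or untested is made for them only; others in the source may bear on it.

In an ADME assay on the whole organism (strain S2) for cytotoxicity, with Drosophila as the target, read by WST assay (on this read-out lower numbers stand for higher toxicity in this test and higher numbers for lower toxicity in this test), compound 1 `CCCC(=O)c1c(O)c(Cl)c(O)c(Cl)c1O` shows only a limit, > 100000 nM. Going by the values given here, compound 2 `CCCCCCCC(=O)c1c(O)c(Cl)c(O)c(Cl)c1O` gives 88500 nM in this assay, the only plain number here. Among the compounds with values here, the single measured step, an at least 1.1-fold lower number from compound 1 to compound 2 (0.05 log units; that floor lies within the scatter), sits within the scatter. Compound 3 `CCCCCCCCC(=O)c1c(O)c(Cl)c(O)c(Cl)c1O` differs from compound 2 by methyl in place of hydrogen on a saturated chain carbon, seven bonds along the chain from a carbonyl carbon. Because an at least 1.1-fold lower number from compound 1 to compound 2 (0.05 log units; that floor lies within the scatter) stayed within the scatter for a larger chain extension, no step beyond the scatter is expected for this smaller one. The expected step is a 1.1-fold lower number from compound 2 to compound 3 (0.04 log units; within the scatter). Compound 3 is therefore expected at 80000 nM, within a range from 40000 nM to 110000 nM.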

Compound 3, half-maximal cytotoxic concentration: 82800 nM
Compound 3: the middle estimate sits 1.0-fold (0.01 log units) below what was measured; measured number inside the range.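

Adding one more carbon at this position, seven bonds along the chain from a carbonyl carbon, gives a 1.1-fold lower number from compound 2 to compound 3 (0.03 log units; within the scatter) in this assay, so this methyl in place of hydrogen brings no change that can be told from noise. The full pentyl change gives an at least 1.2-fold lower number from compound 1 to compound 3 (0.08 log units; that floor lies within the scatter), which is also no clear change. That step is only a floor, because compound 1 stands at a limit: the limit of > 100000 nM in this assay, at which 1 of the 3 values shown sits.

The compounds shown leave open how large the step from compound 1 truly is. They also leave open whether a longer chain, or an amine or a carboxylic acid on this chain, would move the number beyond the scatter.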